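The source may hold more compounds than are shown below. What is called first, only, known or untested is meant among the compounds shown, and "the series" means these compounds.

Compound 1 `CSc1nc2n(n1)C(c1ccc(O)c(O)c1)C([N+](=O)[O-])=NN2`: 362000 nM
Compound 2 `O=[N+]([O-])C1=CNc2nc(-c3ccco3)nn2C1`: 108000 nM
Compound 3 `O=[N+]([O-])C1=CNc2nc(-c3ccco3)nn2C1c1ccc(O)cc1O`: 119000 nM

These three compounds were tested in an ADME assay on MDCK cells (Canis lupus familiaris) for cytotoxicity; on this read-out lower numbers stand for higher toxicity in this test and higher numbers for lower toxicity in this test. Compound 3 stands second highest of the three numbers; the value of compound 2 lies closest, within the scatter, and the value of compound 1 lies furthest, beyond the scatter. Compound 4 `O=[N+]([O-])C1=CNc2nc(C(F)(F)F)nn2C1c1ccc(O)cc1O` differs from compound 3 by trifluoromethyl in place of furan-2-yl on an aromatic carbon. For the measured compounds named here, the only measured step, a 1.1-fold higher number from compound 2 to compound 3 (0.04 log units; within the scatter), concerns a change on a saturated ring carbon, not on the aromatic carbon changed here, so no measured step bears on this change. With nothing to point either way, no step beyond the scatter is expected, and no change at the digits printed from compound 3 to compound 4 (within the scatter) is the estimated step. Compound 4 is expected to give 119000 nM, in a range from 50000 nM to 300000 nM.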

Compound 4, half-maximal cytotoxic concentration: 258000 nM
Compound 4: middle estimate off by 2.2-fold (0.34 log units), on the low side; measured number inside the range.
By their numbers in this assay, from the lowest: compounds 2 and 3 (each within the scatter of the next); then compounds 4 and 1 (each within the scatter of the next).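

In this assay, for the compounds shown here, there is a 2.2-fold higher number from compound 3 to compound 4 (0.34 log units; beyond the scatter) when trifluoromethyl replaces furan-2-yl on this aromatic carbon, so the group here does shift the read-out, which the earlier compounds could not show. The shift is modest and points towards lower toxicity in this test, with a group that has no ring taking the place of one that does. Nothing available explains the shift. As far as these compounds go, whether furan-2-yl alone gives the lower number, or other rings here would too, stays open. So does the reading for an amine or a phenyl ring on this carbon.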